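This account rests on a few compounds, and the source may have more. Where it says the series, first, only, none or still open, it means among the compounds named here.

Compound 1 `Cc1ccc(Nc2nc(Cl)nc3c2ncn3Cc2ccc(/C=C/C(=O)Nc3ccccc3N)cc2)cc1` gives 43% in a functional assay on HepG2 cells (Homo sapiens) for antiproliferative activity, read by CCK-8 assay, with a stated time of 72 h, tested at 8 uM; a lower number here means a weaker effect, a higher number a stronger effect of the compound at the concentration tested. Compound 2 `Nc1ccccc1NC(=O)/C=C/c1ccc(Cn2cnc3c(NC4CCCCC4)nc(Cl)nc32)cc1` gives 42.7% in this assay.

Compound 2 stands at the lowest of the two numbers, with compound 1 nearest; the step of a number 0.3 percentage points lower from compound 1 to compound 2 (within the scatter) shows that exchanging the group on the nitrogen did not move the read-out beyond the scatter. Compound 3 `Nc1ccccc1NC(=O)/C=C/c1ccc(Cn2cnc3c(NCc4ccccc4)nc(Cl)nc32)cc1` differs from compound 2 by benzyl in place of cyclohexyl on a nitrogen on an aromatic ring. Going by the values given here, only the step from compound 1 to compound 2 bears on this change, and it was within the scatter, so no step beyond the scatter is expected in this assay. Compound 3 is therefore estimated at 43%, between 30% and 56%, a step of a number 0.3 percentage points higher from compound 2 to compound 3 (within the scatter).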

Compound 3, a percentage reported as inhibition, at one concentration (the size of the read-out at that concentration, not a potency): 37.7%
Compound 3: middle estimate off by 5.3 percentage points, on the high side; the measured number falls inside the stated range.
By their numbers in this assay, from the lowest: compounds 3, 2 and 1 (each within the scatter of the next).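

In this assay, the benzyl group brings a number 5 percentage points lower from compound 2 to compound 3 (within the scatter), and against 4-methylphenyl it brings a number 5.3 percentage points lower from compound 1 to compound 3 (within the scatter). Cyclohexyl, 4-methylphenyl and benzyl therefore cannot be told apart on this nitrogen, whether the six-membered ring is aromatic or not, and the benzylamino compound shows that this also holds for a ring set on a carbon rather than directly on the nitrogen. No measurement is available to explain these numbers. The compounds shown leave open whether a group without a carbon-only ring on this nitrogen, such as a simple amine-bearing chain or a carboxylic acid, would step beyond the scatter.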